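The compounds below may be only part of what the source reports. "The series", "measured", "known", "first", "only" and "open" are said of these compounds alone.

Compound 1 `CCc1ccccc1OS(=O)(=O)c1ccc(NC(=O)NCCCCl)cc1` and compound 2 `O=C(NCCCCl)Nc1ccc(S(=O)(=O)Oc2ccc(O)cc2)cc1` share one core and differ in a single place, (4-hydroxyphenyl in place of 2-ethylphenyl on an oxygen). In a functional assay on HT-29 cells (Homo sapiens) for cytotoxicity, read by sulforhodamine B assay, with a stated time of 48 h (on this read-out higher numbers stand for weaker inhibition and lower numbers for stronger inhibition), compound 1 gives 15000 nM, and compound 2 gives 50000 nM, so that this change made a step of a 3.3-fold higher number from compound 1 to compound 2 (0.52 log units; beyond the scatter).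

Compound 3 `CCNC(=O)Nc1cccc(S(=O)(=O)Oc2ccccc2CC)c1` carries a different core; how it differs from the core of compound 1 is not broken down here. In this assay compound 3 gives 33000 nM, a number that sits within the scatter of compound 2 and beyond it from compound 1.

Compound 4 `CCNC(=O)Nc1cccc(S(=O)(=O)Oc2ccc(O)cc2)c1` has not yet been measured. It stands to compound 3 as compound 2 stands to compound 1: 4-hydroxyphenyl in place of 2-ethylphenyl on an oxygen, at the same place, so this is the same change seen once before. Because that change made a step of a 3.3-fold higher number from compound 1 to compound 2 (0.52 log units; beyond the scatter), a step of about a 2.7-fold higher number from compound 3 to compound 4 (0.44 log units; beyond the scatter) is expected here as well, with the single earlier case as its only basis. For compound 4 the number expected in this assay is therefore 90000 nM, estimated to lie between 40000 nM and 200000 nM.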

Compound 4, half-maximal inhibitory concentration: 75000 nM
Beside the measured number, compound 4's estimate is 1.2-fold (0.08 log units) above it, within the range that was stated.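

Carried to a second core, 4-hydroxyphenyl in place of 2-ethylphenyl on an oxygen whose other neighbour is the sulfonyl sulfur made a 2.3-fold higher number from compound 3 to compound 4 (0.36 log units; beyond the scatter) in this assay. The change raised the number on both cores, and the sizes of the two steps do not differ beyond the scatter: the same change on two cores in this assay, a 3.3-fold higher number (0.52 log units; beyond the scatter) from compound 1 to compound 2 and a 2.3-fold higher number (0.36 log units; beyond the scatter) from compound 3 to compound 4, 1.5-fold (0.17 log units) apart, within the scatter of two such steps. This shows that the step carried over between these two cores in this one read-out, but two cases make no rule for other cores and say nothing about why the number rises.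

The compounds shown leave open whether a similar step would appear with other groups on that oxygen, such as a phenyl ring bearing an amine or a carboxylic acid in place of the hydroxyl. They also leave open whether the step would hold on a core carrying a chain longer than any of those seen here.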